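The compounds below may be only part of what the source reports. "The series", "measured", "known", "first", "only" and "open" are said of these compounds alone.

Measured so far in a toxicity assay on THP-1 cells (Homo sapiens) for inhibition; on this read-out higher numbers stand for lower toxicity in this test and lower numbers for higher toxicity in this test:
Compound 1 `Cn1c(-c2ccc(Br)cc2)cnc1NC(=O)c1ccc(F)cc1` gives 46000 nM.
Compound 2 `COc1ccc(-c2cnc(NC(=O)c3cnco3)n2C)cc1` gives > 100000 nM, a limit of the test.
Compound 3 `COc1ccc(-c2noc(NC(=O)c3ccc(F)cc3)c2C)cc1` gives > 100000 nM, a limit of the test.

Compound 2 stands at the limit of > 100000 nM in this assay, at which 2 of the 3 values shown sit. For compound 2 this read-out returns a limit and no number. Compound 3 reaches the same limit. Compound 1 gives a number, which sits apart from the two limits but not far from them. Within the data shown here, no pair here differs in only one place, so no measured step is available.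

Compound 4 `COc1ccc(-c2cnc(NC(=O)C3CCCCC3)n2C)cc1` differs from compound 2 in one place: cyclohexyl in place of 1,3-oxazol-5-yl on a carbonyl carbon. The change sits on a carbonyl carbon whose other neighbour is an amide-type nitrogen. Nothing measured in this series shows what such a change does to cytotoxicity. With compound 2 sitting at the limit of > 100000 nM in this assay, at which 2 of the 3 values shown sit, a step of a number no higher from compound 2 to compound 4 (the limit leaves the size open) is expected, which is no move beyond the scatter. The likeliest outcome is that compound 4 also reaches only the limit. Compound 4 is expected at 100000 nM, with a range of 40000 nM to 200000 nM.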

Compound 4, half-maximal cytotoxic concentration: > 100000 nM
Compound 4: no number, only a limit; the forecaster's own chance of this, stated with the estimate: 60%; the middle value lies on the limit itself.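

Compound 2 and compound 4 each return only a limit, so no step between them can be read in this assay: the limit of > 100000 nM in this assay, at which 3 of the 4 values shown sit.

The compounds shown leave open whether cyclohexyl in place of 1,3-oxazol-5-yl on a carbonyl carbon alters cytotoxicity at all.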